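A few compounds are considered here, and "the series" means these few. Any claim that something is new, unique, unknown or untested is made for them only; others in the source may bear on it.

The study concerns compounds built on one shared core. In an assay on cells for inhibition of Voltage-dependent T-type calcium channel subunit alpha-1G (Homo sapiens), read by patch clamp (on this read-out higher numbers stand for weaker inhibition and lower numbers for stronger inhibition), compound 1 `O=C(CC1c2ccccc2N=C(SCCCCCN2CCCC2)N1c1ccccc1)NCc1ccc(F)cc1` gives 13500 nM. In this assay compound 2 `CN(C)CCCCCSC1=Nc2ccccc2C(CC(=O)NCc2ccccc2)N1c1ccccc1` gives 18500 nM, a number that sits alongside that of compound 1 within the usual scatter, so nothing separates the two. Compound 3 `CN(C)CCCCCSC1=Nc2ccccc2C(CC(=O)NCc2ccc(F)cc2)N1c1ccccc1` differs from compound 2 by fluoro in place of hydrogen on an aromatic carbon. Within the data shown here, no step between two measured compounds that differ in one place is available. In this assay the expected step is a 1.3-fold lower number from compound 2 to compound 3 (0.12 log units; within the scatter), a small move toward a lower number that is not clearly beyond the scatter. Compound 3 is therefore estimated at 14000 nM, between 7000 nM and 28000 nM.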

Compound 3, half-maximal inhibitory concentration: 555000 nM
Compound 3: middle estimate off by 40-fold (1.60 log units), on the low side, and the stated range ends below it.
By their numbers in this assay, from the lowest: compounds 1 and 2 (each within the scatter of the next); then compound 3.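

Fluoro in place of hydrogen on this aromatic carbon gives a 30-fold higher number from compound 2 to compound 3 (1.48 log units; beyond the scatter) in this assay, so with the dimethylamino chain end this position is far from indifferent to the change. With the fluoro kept, dimethylamino in place of pyrrolidin-1-yl gives a 41-fold higher number from compound 1 to compound 3 (1.61 log units; beyond the scatter), so the chain end also matters strongly in the 4-fluorobenzyl series. No available evidence bears on the size of these steps. The compounds shown leave open whether chloro or methoxy at this carbon would behave like fluoro, and how the pyrrolidin-1-yl compound with a plain benzyl group would stand.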